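The compounds below may be only part of what the source reports. "The series", "measured", "known", "first", "only" and "open" are said of these compounds alone.

Measured so far:
Compound 1 `CC(C)C[C@H](N)c1ccccc1N1CCN(C(=O)[C@H](C)Cc2ccc(Cl)cc2F)CC1` gives 67 nM in an assay on HEK293 cells for displacement of a labelled ligand from Melanocortin receptor 4 (Homo sapiens); a lower number here means a stronger inhibitor, a higher number a weaker inhibitor.
Compound 2 `CC(C)C[C@H](N)c1cc(Cl)ccc1N1CCN(C(=O)C(C)Cc2ccc(Cl)cc2)CC1` gives 67 nM in this assay.
Compound 3 `CC(C)C[C@H](N)c1cc(C(F)(F)F)ccc1N1CCN(C(=O)CCC(N)=O)CC1` gives only a limit of the assay in this assay, > 10000 nM.

Compound 3 therefore stands at the weak end of the numbers shown, where (the limit of > 10000 nM in this assay, at which 1 of the 3 values shown sits). Compound 4 `CC(C)C[C@H](N)c1cc(C(F)(F)F)ccc1N1CCN(C(=O)[C@H](C)Cc2ccc(Cl)cc2)CC1` differs from compound 3 by 1-(4-chlorobenzyl)ethyl in place of 2-carbamoylethyl on a carbonyl carbon. Among the measured compounds shown here, no measured pair isolates this change, but the group that enters resembles the chlorobenzyl-bearing ethyl group on the same carbonyl in compound 1, which gives 67 nM, and in compound 2, which gives 67 nM. The step expected an at least 140-fold lower number from compound 3 to compound 4 (2.15 log units; beyond the scatter) is large, toward stronger binding, well beyond the scatter. Compound 4 is estimated at 70 nM, with a range from 15 nM to 400 nM.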

Compound 4, inhibition constant: 31 nM
Compound 4: middle estimate off by 2.3-fold (0.35 log units), on the high side; measured number inside the range.
By their numbers in this assay, from the lowest: compound 4; then compounds 1 and 2 (each within the scatter of the next). At a limit, above all of these: compound 3.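

On the carbonyl carbon, with the rest of the molecule unchanged, 1-(4-chlorobenzyl)ethyl in place of 2-carbamoylethyl gives an at least 320-fold lower number from compound 3 to compound 4 (2.50 log units; beyond the scatter) in this assay, the only one-place step shown in the series. This places a large dependence of the read-out on the group at this position, with compound 4 at 31 nM. The value of compound 3 is a limit of the assay, not a number: the limit of > 10000 nM in this assay, at which 1 of the 4 values shown sits.

The compounds shown leave open whether the chlorine, the aromatic ring or the loss of the carbamoyl group carries the step. On these data alone, how an amine or a carboxylic acid at the end of the chain would read in this assay also remains open.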